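The source may hold more compounds than are shown below. What is called first, only, known or untested is meant among the compounds shown, and "the series" means these compounds.

Values in a functional assay on MCF7 cells (Homo sapiens) for inhibition, read by MTT assay, with a stated time of 72 h; a higher number here means a weaker inhibitor, a lower number a stronger inhibitor:
- Compound 1 `O=[N+]([O-])c1ccc(-c2nnc(SCCCN3CCN(c4nc5ccccc5o4)CC3)o2)cc1`: 90100 nM
- Compound 2 `Clc1ccc(-c2nnc(SCCCN3CCN(c4nc5ccccc5o4)CC3)o2)cc1`: 99700 nM

Within the data shown here, compound 2 and compound 1 are the only two compounds measured so far, and their values lie within the usual scatter of each other, so they cannot be ranked. Compound 3 `Fc1ccc(-c2nnc(SCCCN3CCN(c4nc5ccccc5o4)CC3)o2)cc1` differs from compound 2 at one place, with fluoro in place of chloro on an aromatic carbon, para to a large group: fluoro in place of chloro on an aromatic carbon. Among the measured compounds shown here, one measured step bears on this change: a 1.1-fold higher number from compound 1 to compound 2 (0.04 log units; within the scatter), which is chloro in place of nitro on an aromatic carbon. Swapping that group left the number within the scatter, though a single step is thin evidence. No step beyond the scatter is therefore expected in this assay. The expected change is a 1.0-fold lower number from compound 2 to compound 3 (0.02 log units; within the scatter). For compound 3 the estimated value is 95000 nM, with an expected range of 50000 nM to 170000 nM.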

Compound 3, half-maximal inhibitory concentration: 52300 nM
Estimate against measurement, compound 3: 1.8-fold (0.26 log units) above; the range from low to high includes it.
By their numbers in this assay, from the lowest: compounds 3, 1 and 2 (each within the scatter of the next).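

In this assay the position on the aromatic carbon, para to a large group, now has three groups to compare. The change from 4-chlorophenyl to 4-fluorophenyl gives a small step (a 1.9-fold lower number from compound 2 to compound 3 (0.28 log units; within the scatter)), and fluoro in place of nitro gives another (a 1.7-fold lower number from compound 1 to compound 3 (0.24 log units; within the scatter)). Among these compounds, both lie within the scatter, so nitro, chloro and fluoro cannot be told apart at this position, which rests on more than the single step available before, and no separate measurement is at hand to explain this result.

The compounds shown leave open whether an amine, a carboxylic acid or a methoxy group at this position would move the number beyond the scatter. They also leave open whether a longer chain in place of the one in the shared core would do so.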